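The source may report more compounds than this note shows. Statements on the series, on what has been measured and on what is new or still open speak of the compounds shown alone.

Of the compounds shown here, three that share a core have been measured in a physicochemical assay for acid dissociation. Compound 1 `COc1ccc(F)cc1CNCCCNc1ccnc2cc(C3CCCCC3)ccc12` gives 9.47. Compound 2 `c1ccc(CCc2ccc3c(NCCCNCc4ccco4)ccnc3c2)cc1` gives 9.47, and compound 3 `FC(F)(F)c1cc(-c2ccc3c(NCCCNCc4ccco4)ccnc3c2)cc(C(F)(F)F)c1` gives 9.47. Compound 2 therefore stands level with compound 1 and with compound 3 at the digits shown, and both gaps lie within the scatter of a measurement of this kind, so nothing separates the three on this read-out.

The change from compound 2 to compound 4 `Fc1ccc(Cc2ccc3c(NCCCNCc4ccco4)ccnc3c2)c(Cl)c1` is 2-chloro-4-fluorophenyl in place of benzyl on a saturated chain carbon bound to an aromatic carbon. Compound 4 keeps the core and the chain of compound 2, and the exchange happens at the aryl group that sits on the saturated chain carbon bound to an aromatic carbon.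

Going by the values given here, no step between measured compounds is available to show directly what such an exchange does. What the data do show is that compound 1 at 9.47, compound 2 at 9.47 and compound 3 at 9.47 carry different aromatic groups yet return the same value. On that basis the step from compound 2 to compound 4 is expected to be a number 0.02 log units lower from compound 2 to compound 4 (within the scatter), that is, nothing beyond the scatter in either direction. Compound 4 is accordingly estimated to give 9.45, within a range from 9.15 to 9.75.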

Compound 4, acid dissociation constant: 9.47
For compound 4 the middle estimate is 0.02 log units below the measured one; the measured number falls inside the stated range.
By their numbers in this assay, from the lowest: compounds 1, 2, 3 and 4 (each within the scatter of the next).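

In this assay, going by these compounds alone, putting 2-chloro-4-fluorophenyl in place of benzyl on a saturated chain carbon bound to an aromatic carbon gives no change at the digits printed from compound 2 to compound 4 (within the scatter) and this is the first comparison here between two compounds that differ in one place only. The earlier compounds shown here differ from one another in more than one place, so their matching values could not isolate this position, whereas this pair shows that one specific exchange there leaves the read-out level, even though the entering group brings a chlorine and a fluorine and one carbon fewer. No measurement is available that would explain this result, so it stands as an observation only.

As far as these compounds go, both groups compared carry a six-membered aromatic ring of carbon only and no net charge, so it remains open whether the value would stay level with an amine, a carboxylic acid or a longer chain at this position. From the compounds shown here alone, it is also open whether the same exchange would read alike on a compound that differs elsewhere, such as compound 1, which has a different group at the far end of its side chain.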